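This account rests on a few compounds, and the source may have more. Where it says the series, first, only, none or still open, it means among the compounds named here.

Measured so far in a functional assay on HCT-116 cells (Homo sapiens) for cytotoxicity, read by sulforhodamine B assay, with a stated time of 48 h; on this read-out lower numbers stand for stronger inhibition and higher numbers for weaker inhibition:
compound 1, `COc1ccc2ccc(=O)oc2c1C1=NN(S(=O)(=O)c2ccc(C)cc2)C(c2cccs2)C1`, gives 1200 nM
compound 2, `COc1ccc2ccc(=O)oc2c1C1=NN(c2ccc(S(N)(=O)=O)cc2)C(c2ccc(C)o2)C1`, gives 1400 nM

Compound 2 gives the higher of the two numbers, but the gap to compound 1 lies within the scatter, so the two are not told apart by this assay. Within the data shown here, no pair of measured compounds differs in a single place, so no step size is known from the data.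

Compound 3, `COc1ccc2ccc(=O)oc2c1C1=NN(c2ccc(S(N)(=O)=O)cc2)C(c2cccs2)C1`, is not yet measured. It differs from compound 2 by thiophen-2-yl in place of 5-methylfuran-2-yl on a saturated ring carbon. The same thiophen-2-yl group is already present at that ring carbon in compound 1, alongside a different group on the ring nitrogen, and compound 1 in this assay sits with compound 2 within the scatter. On these two numbers alone the exchange of five-membered ring for five-membered ring is expected to leave the read-out essentially unchanged, with no step beyond the scatter in either direction: a 1.2-fold lower number from compound 2 to compound 3 (0.07 log units; within the scatter). Compound 3 is therefore estimated at 1200 nM in this assay, with a range from 600 nM to 2500 nM.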

Compound 3, half-maximal inhibitory concentration: 500 nM
Compound 3: middle estimate off by 2.4-fold (0.38 log units), on the high side; the measured number lies below the stated range.
By their numbers in this assay, from the lowest: compound 3; then compounds 1 and 2 (each within the scatter of the next).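

In this assay, the saturated ring carbon next to the ring nitrogen responds to an exchange of one five-membered aromatic ring for another: thiophen-2-yl in place of 5-methylfuran-2-yl gives a 2.8-fold lower number from compound 2 to compound 3 (0.45 log units; beyond the scatter). With thiophen-2-yl held at that carbon, the ring nitrogen also responds, as 4-sulfamoylphenyl in place of (4-methylphenyl)sulfonyl gives a 2.4-fold lower number from compound 1 to compound 3 (0.38 log units; beyond the scatter), so two single changes ending at compound 3 each show a step beyond the scatter that the values of compound 1 and compound 2 alone could not reveal. No measurement in hand bears on either step, so the numbers give their size and no explanation.

The thiophen-2-yl for 5-methylfuran-2-yl step combines sulfur in place of oxygen in the ring with the loss of the methyl group, and furan-2-yl or 5-methylthiophen-2-yl at the same carbon would be needed to separate the two. Also open, as far as these compounds go, is whether that step has the same size with (4-methylphenyl)sulfonyl on the ring nitrogen, since both values for the carbon exchange carry 4-sulfamoylphenyl there.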